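Oxolan-3-yl in place of a branched ether chain

The source may report more compounds than this note shows. Statements on the series, on what has been measured and on what is new or still open speak of the compounds shown alone.

Among the measured compounds shown here, in an in vitro ADME assay on microsomes (Rattus norvegicus) for metabolic stability (a higher number here means faster removal of the compound, a lower number slower removal), compound 2 `CCC(COC)N(CC(=O)Nc1cc(F)cc(F)c1)C(=O)c1ccc(-c2ccccn2)cc1` gives 6.7 mL.min-1.g-1, the higher of the two numbers so far, while compound 1 `O=C(CN(C(=O)c1ccc(-c2ccccn2)cc1)C1CCOCC1)Nc1cc(F)cc(F)c1` gives 0.6 mL.min-1.g-1. Compound 3 `O=C(CN(C(=O)c1ccc(-c2ccccn2)cc1)C1CCOC1)Nc1cc(F)cc(F)c1` carries oxolan-3-yl in place of 1-(methoxymethyl)propyl on an amide-type nitrogen. For the measured compounds named here, one measured step bears on this change: an 11-fold higher number from compound 1 to compound 2 (1.05 log units; beyond the scatter), large and beyond the scatter, with 1-(methoxymethyl)propyl in place of oxan-4-yl on an amide-type nitrogen. Going by the values given here, compound 3 removes that same chain, but no measured compound carries oxolan-3-yl, so only part of that step is assumed to carry over. The expected change is a 5.6-fold lower number from compound 2 to compound 3 (0.75 log units; beyond the scatter), a step to a lower number and beyond the scatter, though somewhat smaller than the measured one. For compound 3 the estimated value is 1.2 mL.min-1.g-1, with an expected range of 0.5 mL.min-1.g-1 to 3.5 mL.min-1.g-1.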

Compound 3, intrinsic clearance in microsomes in the Rattus norvegicus assay: 3.2 mL.min-1.g-1
Compound 3: middle estimate off by 2.7-fold (0.43 log units), on the low side, and the stated range covers the measured number.
By their numbers in the Rattus norvegicus assay, from the lowest: compound 1; then compound 3; then compound 2.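

In the Rattus norvegicus assay the step is a 2.1-fold lower number from compound 2 to compound 3 (0.32 log units; beyond the scatter), so oxolan-3-yl on the amide-type nitrogen recovers only part of the gap to oxan-4-yl. The choice between these two rings also counts at this position: in the Rattus norvegicus assay the step is a 5.3-fold higher number from compound 1 to compound 3 (0.73 log units; beyond the scatter), which leaves compound 1 with the lowest number of the three. In a physicochemical assay for solubility, read by chemiluminescence (on this read-out lower numbers stand for lower solubility and higher numbers for higher solubility), compound 2 gives 24 ug/mL, while compound 3 gives 102 ug/mL. Oxolan-3-yl in place of 1-(methoxymethyl)propyl also comes with a higher number in the physicochemical assay: the measured solubility of compound 2, 24 ug/mL, and of compound 3, 102 ug/mL, a 4.3-fold higher number (0.63 log units; beyond the scatter)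

Still open, on these data alone, is whether the difference between oxan-4-yl and oxolan-3-yl persists with a ring amine at this position, such as piperidin-4-yl or pyrrolidin-3-yl. Also open, as far as these compounds go, is how an open chain without the ether oxygen, such as pentan-3-yl, would stand against 1-(methoxymethyl)propyl in the Rattus norvegicus assay and in the physicochemical assay.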